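A few compounds are considered here, and "the series" means these few. Any claim that something is new, unique, unknown or untested is made for them only; others in the source may bear on it.

Values so far, in a toxicity assay on cells (Macrophage, Homo sapiens) for inhibition, read by MTT assay; on this read-out lower numbers stand for stronger inhibition and higher numbers for weaker inhibition:
- compound 1 `CN1CCN(CCCNc2nc(-c3ccc(F)cc3)nc3ccccc23)CC1`: 40000 nM
- compound 2 `NCCNc1nc(-c2ccc(F)cc2)nc2ccccc12`: 64000 nM

Within the data shown here, compound 2 lies within the scatter of compound 1, the only other measured compound. Compound 3 `NCCCCNc1nc(-c2ccc(F)cc2)nc2ccccc12` follows from compound 2 by 2-aminoethyl in place of amino on a saturated chain carbon, two bonds along the chain from a nitrogen on an aromatic ring. Among the measured compounds shown here, the one measured step at this place, a 1.6-fold higher number from compound 1 to compound 2 (0.20 log units; within the scatter), is small, though it involves a different group. No step beyond the scatter is therefore expected in this assay. The estimated step is a 1.3-fold lower number from compound 2 to compound 3 (0.11 log units; within the scatter). Compound 3 is expected at 50000 nM, with an estimated range of 20000 nM to 110000 nM.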

Compound 3, half-maximal inhibitory concentration: 64000 nM
Beside the measured number, compound 3's estimate is 1.3-fold (0.11 log units) below it; the range from low to high includes it.
By their numbers in this assay, from the lowest: compounds 1, 2 and 3 (each within the scatter of the next).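

In this assay, 2-aminoethyl in place of amino on the saturated chain carbon gives no change at the digits printed from compound 2 to compound 3 (within the scatter), so this change of chain group leaves the read-out within the scatter. Aminomethyl in place of 4-methylpiperazin-1-yl, three bonds along the chain from a nitrogen on an aromatic ring, gives a 1.6-fold higher number from compound 1 to compound 3 (0.20 log units; within the scatter), so no step among compounds 1, 2 and 3 lies beyond the scatter. No evidence bears on these results.

On these data alone, whether a longer chain, or a carboxylic acid or hydroxyl at the chain end, would give a step beyond the scatter remains open.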